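Three amide variants and an ester analogue in the same series

The source may report more compounds than this note shows. Statements on the series, on what has been measured and on what is new or still open speak of the compounds shown alone.

Compound 1 `COc1cc(/C=C/C(=O)c2cccc(NC(=O)c3c(Cl)cccc3Cl)c2)ccc1O` carries a 2,6-dichlorophenyl on its amide carbonyl. In a functional assay on U-87MG ATCC cells (Homo sapiens) for inhibition (a lower number here means a stronger inhibitor, a higher number a weaker inhibitor), compound 1 gives 17.8 ug/mL, the highest of the three numbers measured. Compound 2 `COc1cc(/C=C/C(=O)c2cccc(NC(=O)c3cccs3)c2)ccc1O` gives 14.7 ug/mL in this assay, and compound 3 `COc1cc(/C=C/C(=O)c2cccc(NC(=O)c3ccco3)c2)ccc1O` gives 6.65 ug/mL. The step of a 1.2-fold lower number from compound 1 to compound 2 (0.08 log units; within the scatter) lies within the scatter, whereas a 2.7-fold lower number from compound 1 to compound 3 (0.43 log units; beyond the scatter) and a 2.2-fold lower number from compound 2 to compound 3 (0.34 log units; beyond the scatter) are modest but real.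

Compound 4 `COC(=O)C(=O)Nc1cccc(C(=O)/C=C/c2ccc(O)c(OC)c2)c1` differs from compound 1 as follows: methoxycarbonyl in place of 2,6-dichlorophenyl on a carbonyl carbon. For the measured compounds named here, no measured step covers a methoxycarbonyl at this position; the steps from compound 1 only show that taking the 2,6-dichlorophenyl away in favour of a smaller group left the number either unchanged or modestly lower. On that slim basis a number close to that of compound 1, or somewhat lower, is expected for compound 4, with the step of a 1.3-fold lower number from compound 1 to compound 4 (0.10 log units; within the scatter) uncertain in either direction. The estimate for compound 4 in this assay is 14 ug/mL, with a range from 5 ug/mL to 40 ug/mL.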

Compound 4, half-maximal inhibitory concentration: 12.2 ug/mL
Compound 4: middle estimate off by 1.1-fold (0.06 log units), on the high side, within the range that was stated.
By their numbers in this assay, from the lowest: compounds 3, 4, 2 and 1 (each within the scatter of the next, the first and the last beyond it).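

In this assay, the methoxycarbonyl of compound 4, the only group shown on this carbonyl carbon without a ring, stays within the scatter of all three ring-bearing groups (a 1.5-fold lower number from compound 1 to compound 4 (0.16 log units; within the scatter) and a 1.2-fold lower number from compound 2 to compound 4 (0.08 log units; within the scatter) and a 1.8-fold higher number from compound 3 to compound 4 (0.26 log units; within the scatter)). A ring at this position is therefore not required for a number in this range, and compound 4 cannot be ranked against any of the other three, even though compounds 1 and 3 are separated beyond the scatter. Nothing available accounts for these numbers.

From the compounds shown here alone, whether a carboxylic acid, an amine or a longer alkyl chain on this carbonyl carbon would move the number beyond the scatter remains open. So does whether the small gaps seen here would hold on a different core.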